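Trading a methyl for hydrogen on a phenol oxygen

A few compounds are considered here, and "the series" means these few. Any claim that something is new, unique, unknown or untested is made for them only; others in the source may bear on it.

Compound 2 `COc1cc(Cl)c(C(=O)Nc2cccc(-c3nc4ccccc4s3)c2)cc1[N+](=O)[O-]` and compound 1 `Cc1cc(NC(=O)c2cc([N+](=O)[O-])ccc2Cl)cc(-c2nc3ccccc3s2)c1O` share a core and differ only in the groups around it. In an ADME assay on HEK293 cells (Homo sapiens) for cytotoxicity, with a stated time of 72 h (a lower number here means that less compound is needed, a higher number that more compound is needed for the effect), compound 2 gives only a limit of the assay, > 25000 nM. Compound 1 likewise reaches only a limit, > 25000 nM. Both values sit at one point, as the limit of > 25000 nM in this assay, at which 2 of the 2 values shown sit, shows. Compound 3 `O=C(Nc1cccc(-c2nc3ccccc3s2)c1)c1cc([N+](=O)[O-])c(O)cc1Cl` differs from compound 2 in a single place: hydrogen in place of methyl on an oxygen on an aromatic ring. For the measured compounds named here, with no step measured here, the move a step that the limit leaves unreadable from compound 2 to compound 3 is expected to stay within the usual scatter, near the limit. Compound 3 is therefore estimated at 30000 nM, within 12000 nM to 80000 nM.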

Compound 3, half-maximal effective concentration: > 25000 nM
Compound 3 was reported as a limit; the forecaster's own chance of this, stated with the estimate: 85%; the middle value is on the limit's open side.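

Compound 3 gives > 25000 nM in this assay, which is a limit and not a number. For the compounds shown here, compound 2 also gives only a limit, so no step from compound 2 to compound 3 can be read. Whether methoxy to hydroxy changes the concentration needed for the effect stays open: the limit of > 25000 nM in this assay, at which 3 of the 3 values shown sit.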